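A few compounds are considered here, and "the series" means these few. Any claim that something is new, unique, unknown or untested is made for them only; others in the source may bear on it.

Compound 1 `COc1ccc(S(=O)(=O)N(C)CCOCC(=O)N(C)Cc2ccc(C3=NCCN3)cc2)c(C)c1`: 5.5 nM
Compound 2 `COc1cc(C)c(S(=O)(=O)N(C)CCOCC(=O)N2CCC(C(C)(C)CN(C)C)CC2)c(C)c1`: 10 nM
Compound 3 `COc1cc(C)c(S(=O)(=O)N(C)CCOCC(=O)N2CCN([C@@H]3CN4CCC3CC4)CC2)c(C)c1`: 5.6 nM

All three were measured in an assay on HEK293 cells for displacement of a labelled ligand from B1 bradykinin receptor (Homo sapiens), read by scintillation counting; on this read-out higher numbers stand for weaker inhibition and lower numbers for stronger inhibition. Compound 2 gives the highest of the three numbers, yet its gaps to compound 3 and to compound 1 both fall within the scatter, so no order among them can be claimed. Compound 4 `COc1cc(C)c(S(=O)(=O)N(C)CCOCC(=O)N2CCC(C3CCN(C(C)C)CC3)CC2)c(C)c1` has not been measured; it differs from compound 2 by 1-isopropylpiperidin-4-yl in place of 1-((dimethylamino)methyl)-1-methylethyl on a saturated ring carbon. Going by the values given here, no step between measured compounds isolates such a change. Compound 3, which carries a different amine-bearing group at this end of the shared core, reaches 5.6 nM in this assay. The step from compound 2 to compound 4 is expected to be a 1.3-fold lower number from compound 2 to compound 4 (0.10 log units; within the scatter), that is, nothing beyond the scatter. Compound 4 is therefore estimated at 8 nM, within a range from 2.5 nM to 30 nM.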

Compound 4, inhibition constant: 0.4 nM
The estimate for compound 4 lay 20-fold (1.30 log units) above the measured number, and the stated range ends above it.
By their numbers in this assay, from the lowest: compound 4; then compounds 1, 3 and 2 (each within the scatter of the next).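

At this saturated ring carbon, 1-isopropylpiperidin-4-yl in place of 1-((dimethylamino)methyl)-1-methylethyl gives, in this assay, a 25-fold lower number from compound 2 to compound 4 (1.40 log units; beyond the scatter), the first step shown beyond the scatter. The change brings in a six-membered non-aromatic ring while the count of hydrogen-bond acceptors stays the same, so this end of the molecule can move the number strongly even without a change in that count. Nothing at hand accounts for the size of this step.

The compounds shown do not separate the contribution of the ring from that of its isopropyl group. As far as these compounds go, how a methyl or a cyclopropyl in place of that isopropyl would read remains open.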